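Allosteric Modulator Series: Carboxyphenyl Ether Variations Compared

This account rests on a few compounds, and the source may have more. Where it says the series, first, only, none or still open, it means among the compounds named here.

The measured compounds are compound 1 `Cc1c(OCCCCOc2ccc(C(=O)O)cc2Cl)ccc(C(=O)CC(C)C)c1O` with 99.5% and compound 2 `Cc1c(OCCCCOc2cccc(C(=O)O)c2)ccc(C(=O)CC(C)C)c1O` with 84.5%.

In an assay on HEK293 cells for positive allosteric modulation of metabotropic glutamate receptor 2 (Rattus norvegicus), read by thallium flux, with a stated time of 2.5 min (a lower number here means a smaller maximal response, a higher number a larger maximal response), compound 1 gives 99.5%. Among the measured compounds shown here, compound 2 stands lowest of the two numbers known in this assay, where compound 2 gives 84.5%, and its nearest neighbour is compound 1, the step being a number 15 percentage points lower from compound 1 to compound 2 (beyond the scatter).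

Compound 3 `Cc1cc(OCCCCOc2ccc(C(=O)CC(C)C)c(O)c2C)ccc1C(=O)O` has not yet been measured in this assay. It differs from compound 2 by 4-carboxy-3-methylphenyl in place of 3-carboxyphenyl on an oxygen on a saturated carbon.

For the measured compounds named here, the only measured step that bears on this change is a number 15 percentage points lower from compound 1 to compound 2 (beyond the scatter), in which a 4-carboxy-2-chlorophenyl gave way to a 3-carboxyphenyl. Going by the values given here, compound 3 brings back a 4-carboxyphenyl pattern, now carrying a methyl in place of the chlorine, so in this assay a step of about that size is expected, in the upward direction, since the one step known in this direction was a number 15 percentage points lower from compound 1 to compound 2 (beyond the scatter). The expected step from compound 2 is a number 10.5 percentage points higher from compound 2 to compound 3 (beyond the scatter). Compound 3 is therefore estimated at 95%, with a range from 80% to 110%.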

Compound 3, largest response reached (reported as percent of maximum), in percent of the reference or control that the assay uses: 93.3%
The estimate for compound 3 lay 1.7 percentage points above the measured number, and the stated range covers the measured number.
By their numbers in this assay, from the lowest: compounds 2, 3 and 1 (each within the scatter of the next, the first and the last beyond it).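

In this assay, the 4-carboxy-3-methylphenyl group on an oxygen on a saturated carbon cannot be told apart from the 3-carboxyphenyl group that it replaces, with a number 8.8 percentage points higher from compound 2 to compound 3 (within the scatter) as the step. Nor can it be told apart from the 4-carboxy-2-chlorophenyl group, with a number 6.2 percentage points lower from compound 1 to compound 3 (within the scatter) as the step. Among the compounds shown here, until now this place had offered only one comparison, and that one lay beyond the scatter; compound 3 now sits within the scatter of both compound 1 and compound 2, so the three compounds no longer divide into two separate levels of maximal response, even though compound 1 and compound 2 remain apart. The result also shows that a high maximal response at this place does not depend on the chlorine, since compound 3 carries a methyl instead and stays within the scatter of compound 1.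

The compounds shown leave open how a 4-carboxyphenyl group with neither chlorine nor methyl would compare, and whether a tetrazole could stand in for the carboxylic acid at this place. Nothing among the data shown accounts for the small differences seen among the three compounds.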